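The compounds below may be only part of what the source reports. "The series", "measured", "known", "first", "only" and "open" are said of these compounds alone.

Series: an assay on Cerebral cortex for displacement of a labelled ligand from adenosine receptor A1 (Bos taurus); a lower number here means a stronger inhibitor, a higher number a weaker inhibitor

Compound 1 `CNc1nc(-c2ccccc2)nc2c1nnn2Cc1ccccc1Cl` — 191 nM
Compound 2 `Clc1ccccc1Cn1nnc2c(NC3CCC3)nc(-c3ccccc3)nc21` — 24 nM

In this assay compound 1 gives 191 nM and compound 2 gives 24 nM; the step of an 8.0-fold lower number from compound 1 to compound 2 (0.90 log units; beyond the scatter) is the only one measured so far, and it leaves compound 2 with the lowest number of the two.

Compound 3 `Clc1ccccc1Cn1nnc2c(NC3CCCC3)nc(-c3ccccc3)nc21` continues along the same position with cyclopentyl in place of cyclobutyl on a nitrogen on an aromatic ring. For the measured compounds named here, the one measured step bears on this directly, since it also enlarged the group on that nitrogen, and it was a gain beyond the scatter. Going from a four-membered to a five-membered ring is a smaller change than methyl to cyclobutyl, so a smaller gain in this assay is expected, of the order of a 2.0-fold lower number from compound 2 to compound 3 (0.30 log units; within the scatter), with no gain beyond the scatter also plausible.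

Compound 3 is estimated at 12 nM in this assay, within 4 nM to 35 nM.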

Compound 3, inhibition constant: 9 nM
Beside the measured number, compound 3's estimate is 1.3-fold (0.12 log units) above it; the range from low to high includes it.
By their numbers in this assay, from the lowest: compound 3; then compound 2; then compound 1.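

In this assay the change from cyclobutylamino to cyclopentylamino gives a 2.7-fold lower number from compound 2 to compound 3 (0.43 log units; beyond the scatter) on this nitrogen, so the gain seen with cyclobutyl continues with the next ring and does not stop at the four-membered one. Taken across the position, cyclopentyl in place of methyl gives a 21-fold lower number from compound 1 to compound 3 (1.33 log units; beyond the scatter) and is the largest step in the series so far, and with both of its steps beyond the scatter, compound 3 holds the lowest number of the three, with no compound going against the order methyl, cyclobutyl, cyclopentyl. Nothing at hand explains why the number falls along this order.

On these data alone, whether cyclohexyl on the same nitrogen lowers the number further or reverses the order remains open. Also open, as far as these compounds go, is whether an open chain such as isopropyl or pentyl matches the cyclopentyl ring here.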